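Swapping Fluoro for Methoxy on an Inactive Dithiocarbamate Pair

This account rests on a few compounds, and the source may have more. Where it says the series, first, only, none or still open, it means among the compounds named here.

Measured so far:
Compound 1, `COc1ccc(Cn2cc(CSC(=S)N3CCNCC3)nn2)cc1`: > 128000 nM
Compound 2, `O=C(OCc1ccccc1)N1CCN(C(=S)SCc2cn(Cc3ccc(F)cc3)nn2)CC1`: > 128000 nM

Both were tested in a functional assay on PC-3 cells (Homo sapiens) for inhibition, read by MTT assay, with a stated time of 72 h; a lower number here means a stronger inhibitor, a higher number a weaker inhibitor. For compound 1 the value > 128000 nM is a limit of the assay, not a measured number. For compound 2 the value > 128000 nM is likewise a limit. Compound 2 therefore stands at the limit of > 128000 nM in this assay, at which 2 of the 2 values shown sit, with nothing measured beyond it.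

Compound 3, `COc1ccc(Cn2cc(CSC(=S)N3CCN(C(=O)OCc4ccccc4)CC3)nn2)cc1`, is reached from compound 2 by methoxy in place of fluoro on an aromatic carbon. The same methoxybenzyl group already sits in compound 1, which also gave only a limit. Going by the values given here, with no measured step to lean on, the expected change is none beyond the scatter, and the step that the limit leaves unreadable from compound 2 to compound 3 is expected to be small. Compound 3 is expected to stay at the limit as well, estimated at 200000 nM with a range from 100000 nM to 600000 nM.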

Compound 3, half-maximal inhibitory concentration: > 128000 nM
Compound 3 gave a limit, no number (the forecaster's own chance of this, stated with the estimate: 85%); the middle value is on the limit's open side.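

No step can be read among compound 1, compound 2 and compound 3, as each gives only a limit and no number: the limit of > 128000 nM in this assay, at which 3 of the 3 values shown sit. The compounds shown leave open whether swapping fluoro for methoxy, or adding benzyloxycarbonyl, changes inhibition at all.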